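Iodo for furan-2-yl on the shared core

The source may report more compounds than this note shows. Statements on the series, on what has been measured and on what is new or still open speak of the compounds shown alone.

Among the compounds with values here, in a functional assay on K562 cells (Homo sapiens), read by MTT assay, with a stated time of 72 h (a lower number here means a stronger inhibitor, a higher number a weaker inhibitor), compound 1 `C#Cc1cn([C@@H]2O[C@H](CO)[C@@H](O)[C@H]2O)c2ncnc(OC)c12` gives 380 nM, the only readable number. Compound 2 `Nc1nc(N)c2c(-c3ccco3)cn([C@@H]3O[C@H](CO)[C@@H](O)[C@H]3O)c2n1` reads > 20000 nM, which is a limit of the assay. Compound 3 `Cc1nc(N)c2c(-c3ccco3)cn([C@@H]3O[C@H](CO)[C@@H](O)[C@H]3O)c2n1` reads > 20000 nM, also a limit, so it stands at the limit of > 20000 nM in this assay, at which 2 of the 3 values shown sit, and has no number of its own.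

Compound 4 `Cc1nc(N)c2c(I)cn([C@@H]3O[C@H](CO)[C@@H](O)[C@H]3O)c2n1` follows from compound 3 by iodo in place of furan-2-yl on an aromatic carbon, with iodo in place of furan-2-yl on an aromatic carbon.

Within the data shown here, the only measured step between close neighbours is a step that the two limits leave unreadable from compound 2 to compound 3, and it concerns another place, so it gives no size to carry over. Among the measured compounds shown here, no measured step covers loss of the furan-2-yl. For the measured compounds named here, the one pointer is compound 1 at 380 nM, which has no furan-2-yl, though it also differs elsewhere. A move towards a stronger inhibitor in this assay is therefore expected, held loosely, and another limit reading remains quite possible.

The expected step is an at least 2.5-fold lower number from compound 3 to compound 4 (0.39 log units; beyond the scatter).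

Compound 4 is estimated at 8000 nM, within an expected range of 600 nM to 40000 nM.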

Compound 4, half-maximal inhibitory concentration: 1110 nM
Estimate against measurement, compound 4: 7.2-fold (0.86 log units) above, and the stated range covers the measured number.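

Iodo in place of furan-2-yl on an aromatic carbon gives an at least 18-fold lower number from compound 3 to compound 4 (1.25 log units; beyond the scatter) in this assay, so the group at this position, two ring bonds from the ring nitrogen, strongly affects the read-out on the shared core. Compound 3 has only a limit of the assay, so the step gives a minimum size and not an exact one, since it starts from that limit: the limit of > 20000 nM in this assay, at which 2 of the 4 values shown sit. Unlike the step from amino to methyl, which cannot be read, this one shows that the methyl-bearing core is not inactive in itself once furan-2-yl has left.

From the compounds shown here alone, whether the change follows from losing furan-2-yl or from gaining iodo stays open; only these two groups are compared here on this core. Chloro or phenyl at the same position would help separate the two readings.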